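Methoxy for methyl on the core: compound 4

The compounds below may be only part of what the source reports. "The series", "measured", "known", "first", "only" and "open" are said of these compounds alone.

Compound 1 `Cc1ccc2ncc(S(=O)(=O)c3ccc(F)cc3)c(N3CCC(C)CC3)c2c1` is the reference point of this small set. In an assay on isolated protein for displacement of a labelled ligand from metabotropic glutamate receptor 5 (Homo sapiens), with a stated time of 60 min, tested at 1 uM (a higher number here means more inhibition at the concentration tested (going by the name of the read-out), a lower number less inhibition), compound 1 gives 90%, the highest of the three numbers. Compound 2 `COc1ccc(S(=O)(=O)c2cnc3ccc(C)cc3c2N2CCC(C)CC2)cc1` gives 62% and compound 3 `Cc1ccc2ncc(S(=O)(=O)c3cc(Cl)cc(Cl)c3)c(N3CCC(C)CC3)c2c1` gives 75%; the steps of a number 28 percentage points lower from compound 1 to compound 2 (beyond the scatter) and a number 15 percentage points lower from compound 1 to compound 3 (beyond the scatter) both lower the read-out, while a number 13 percentage points higher from compound 2 to compound 3 (beyond the scatter) runs the other way. Compound 4 `COc1ccc2ncc(S(=O)(=O)c3ccc(F)cc3)c(N3CCC(C)CC3)c2c1` differs from compound 1 by methoxy in place of methyl on an aromatic carbon. For the measured compounds named here, none of the measured steps touches this position; all three alter the aryl on the sulfonyl sulfur, so they bear only loosely on the change and give no direct guide. A step within the scatter or a modest loss is expected, a number 10 percentage points lower from compound 1 to compound 4 (within the scatter). Compound 4 is therefore estimated at 80%, between 60% and 95%.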

Compound 4, a percentage reported as inhibition, at one concentration (the size of the read-out at that concentration, not a potency): 27%
Beside the measured number, compound 4's estimate is 53 percentage points above it, outside the stated range (below it).
By their numbers in this assay, from the lowest: compound 4; then compound 2; then compound 3; then compound 1.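

In this assay the core position carrying the methyl proves sensitive, with methoxy in place of methyl giving a number 63 percentage points lower from compound 1 to compound 4 (beyond the scatter). That step is larger than either change on the sulfonyl aryl, such as a number 28 percentage points lower from compound 1 to compound 2 (beyond the scatter), so a single added oxygen on the core costs more here than replacing the 4-fluorophenyl. Nothing measured bears on the reason for this loss. As far as these compounds go, whether the loss follows the oxygen or the longer substituent stays open; ethyl, hydroxyl or a bare hydrogen at this position would help separate these. Also open, from the compounds shown here alone, is whether the loss holds with the 3,5-dichlorophenyl on the sulfonyl sulfur.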